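A few compounds are considered here, and "the series" means these few. Any claim that something is new, unique, unknown or untested is made for them only; others in the source may bear on it.

The measured compounds:
compound 1, `COc1cccc(CNCCCNc2ccnc3cc(-c4ccc(F)cc4)ccc23)c1O`: 32000 nM
compound 2, `CCC(CC)c1ccc2c(NCCCNCc3cc(F)ccc3OC)ccnc2c1`: 4200 nM
compound 3, `CCC(CC)c1ccc2c(NCCCNCc3ccco3)ccnc2c1`: 4200 nM

All three were measured in a physicochemical assay for solubility, with a stated time of 18 h, at pH 7.4; on this read-out lower numbers stand for lower solubility and higher numbers for higher solubility. Compound 2 and compound 3 give the same reading at the digits shown, and together they stand lowest of the three; compound 1 stands furthest from compound 2, with a higher number that lies beyond the scatter. Among the compounds with values here, the only step between neighbours that differ in a single place, no change at the digits printed from compound 2 to compound 3 (within the scatter), exchanges the group on the saturated chain carbon bound to an amine nitrogen and leaves the reading where it was.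

Within the data shown here, the unmeasured compound 4, `COc1ccc(F)cc1CNCCCNc1ccnc2cc(Oc3ccc(Cl)cc3)ccc12`, differs from compound 2 elsewhere: 4-chlorophenoxy in place of pentan-3-yl on an aromatic carbon The single measured step touches a different part of the molecule, so it gives no direct guide to what this exchange does; it only shows that a change at the chain end left this assay unmoved. Compound 1 carries a different group where compound 2 carries pentan-3-yl, and also a different chain end, so its higher value cannot be tied to either change alone. Among the measured compounds shown here, with no bearing step, the expected step is a 1.2-fold lower number from compound 2 to compound 4 (0.08 log units; within the scatter), no change beyond the scatter, and the range is kept wide. Compound 4 is therefore estimated at 3500 nM, between 900 nM and 14000 nM.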

Compound 4, solubility: 14500 nM
The estimate for compound 4 lay 4.1-fold (0.62 log units) below the measured number; the measured number lies above the stated range.
By their numbers in this assay, from the lowest: compounds 2 and 3 (each within the scatter of the next); then compound 4; then compound 1.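

In this assay, within the data shown here, putting 4-chlorophenoxy in place of pentan-3-yl on the aromatic carbon gives a 3.5-fold higher number from compound 2 to compound 4 (0.54 log units; beyond the scatter), whereas the only earlier single change, at the chain end, gave no change at the digits printed from compound 2 to compound 3 (within the scatter) and left the reading in place. This is therefore the first single change shown to move the reading beyond the scatter, and it places the sensitivity at this aromatic carbon, at least for this one exchange. The entering group brings a six-membered aromatic ring and a hydrogen-bond acceptor that pentan-3-yl lacks, along with more heavy atoms, but nothing available here says which of these differences, if any, accounts for the higher number.

The compounds shown cannot separate the contributions of the ring, the linking oxygen and the chlorine, and a plain phenoxy group or a simple methoxy group on this carbon would begin to pull these apart. From the compounds shown here alone, it also remains open whether 4-chlorophenoxy would give a similar step alongside the furan-2-yl chain end of compound 3, or whether an amine on this carbon would move the reading further.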